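The compounds below may be only part of what the source reports. "The series", "measured", "known", "first", "only" and "open" are said of these compounds alone.

Compound 1 `COCc1nc(Nc2ccc(C(F)(F)F)cc2)c2ccc(-c3ncccc3C(F)(F)F)cc2n1` gives 1.5 nM in a functional assay for antagonist activity at transient receptor potential cation channel subfamily V member 1 (Homo sapiens); on this read-out higher numbers stand for weaker inhibition and lower numbers for stronger inhibition; compound 2 `OCCCc1nc(Nc2ccc(C(F)(F)F)cc2)c2ccc(-c3ncccc3C(F)(F)F)cc2n1` gives 25 nM in this assay.

Compound 2 thus stands with the highest of the two numbers, and the step of a 17-fold higher number from compound 1 to compound 2 (1.22 log units; beyond the scatter) is large. Compound 3 `FC(F)(F)c1ccc(Nc2nc(CNC3CCCCC3)nc3cc(-c4ncccc4C(F)(F)F)ccc23)cc1` differs from compound 2 by cyclohexylamino in place of 2-hydroxyethyl on a saturated chain carbon bound to an aromatic carbon. Among the compounds with values here, only that one measured step touches the same place, and it shows that a change there can move this assay a long way. Compound 3 is therefore expected to land between the two measured compounds, at 8 nM (range 2 nM to 40 nM), a step of a 3.1-fold lower number from compound 2 to compound 3 (0.49 log units; beyond the scatter) toward a lower number.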

Compound 3, half-maximal inhibitory concentration: 6 nM
Estimate against measurement, compound 3: 1.3-fold (0.12 log units) above; the range from low to high includes it.
By their numbers in this assay, from the lowest: compound 1; then compound 3; then compound 2.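

In this assay, cyclohexylamino on this saturated chain carbon gives a 4.2-fold lower number from compound 2 to compound 3 (0.62 log units; beyond the scatter) and so improves on 2-hydroxyethyl, showing that this place accepts an amine carrying a six-membered ring of carbon only. The same group still gives a 4.0-fold higher number from compound 1 to compound 3 (0.60 log units; beyond the scatter) against methoxy, so it recovers only part of what the earlier step lost. No measurement offered here bears on the cause of either step.

The compounds shown leave open whether a smaller amine such as dimethylamino would match methoxy. They also leave open how a morpholine or a carboxylic acid would fare at this place.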